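Formyl to acetyl at the ring amide nitrogen

This account rests on a few compounds, and the source may have more. Where it says the series, first, only, none or still open, it means among the compounds named here.

Compound 1 `O=CN1N=C(c2ccc(F)cc2)CC1c1cn(-c2ccccc2)nc1-c1ccc(Cl)c(Cl)c1` is the reference point of this small series. In a functional assay on the whole organism (strain Wistar) for inhibition, with Rattus norvegicus as the target, read by paw edema, with stated times of 30 min and 60 min, at a dose of 50 mg/kg by the oral route (a lower number here means less inhibition, a higher number more inhibition at the dose given (going by the name of the read-out)), compound 1 gives 56.5%. Compound 3 `Cc1ccc(C2=NNC(c3cn(-c4ccccc4)nc3-c3ccc(Cl)c(Cl)c3)C2)cc1` gives 56.5%, so compound 1 stands level with compound 3 at the digits recorded, the two together the highest of the three numbers. Among the compounds with values here, compound 2 `O=CN1N=C(c2ccc(Cl)cc2)CC1c1cn(-c2ccccc2)nc1-c1ccc(Cl)c(Cl)c1` gives 51.1%; the single step of a number 5.4 percentage points lower from compound 1 to compound 2 (within the scatter) lies within the scatter, so the aromatic halogen swap has not moved the read-out in any meaningful way.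

Compound 4 `CC(=O)N1N=C(c2ccc(F)cc2)CC1c1cn(-c2ccccc2)nc1-c1ccc(Cl)c(Cl)c1` is the next step from compound 1. The difference is methyl in place of hydrogen on a carbonyl carbon. Within the data shown here, no measured step touches the carbonyl carbon, so nothing measured bears directly on this change; the only measured step sits on the aromatic ring and was within the scatter, and compound 3 and compound 1 show identical values. The expectation for compound 4 is therefore no step beyond the scatter. The step expected from compound 1 to compound 4 is a number 1.5 percentage points lower from compound 1 to compound 4 (within the scatter). Compound 4 is thus estimated at 55%, with a range from 42% to 68%.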

Compound 4, a percentage reported as inhibition, in the whole organism at one dose (the size of the read-out at that dose, not a potency): 59.5%
The estimate for compound 4 lay 4.5 percentage points below the measured number, within the range that was stated.
By their numbers in this assay, from the lowest: compounds 2, 1, 3 and 4 (each within the scatter of the next).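

In this assay, methyl in place of hydrogen on a carbonyl carbon gives a number 3 percentage points higher from compound 1 to compound 4 (within the scatter). Within the data shown here, this is the first measured change at this position, and it shows that going from formyl to acetyl on the amide-type nitrogen in a ring leaves the inhibition at this dose within the scatter, as did the earlier halogen swap on the aromatic carbon. No measured information on any property of the two groups bears on this result.

On these data alone, it remains open whether the read-out stays at this level when the carbonyl carbon carries a longer chain such as propyl, an amine or a phenyl group in place of methyl. Also open, as far as these compounds go, is whether acetyl gives a similar number with chloro in place of fluoro on the aromatic carbon.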